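Series notes: allyl to cyclopropyl on the amide nitrogen

The compounds below may be only part of what the source reports. "The series", "measured", "known", "first", "only" and "open" are said of these compounds alone.

The three measured compounds share one core and differ at two places. Compound 1 `C/C(C(=O)NC1CC1)=C(/C)c1ccc(Br)cc1` gives 130 mg/kg in a toxicity assay on the whole organism (strain Icem-CET (SPF Caw)) for cytotoxicity, with Mus musculus as the target; a lower number here means that less compound is needed, a higher number that more compound is needed for the effect; compound 2 `C/C(C(=O)NC1CC1)=C(/C)c1ccc(F)cc1` gives 70 mg/kg in this assay; compound 3 `C=CCNC(=O)/C(C)=C(\C)c1ccc(C)cc1` gives 150 mg/kg in this assay. For the measured compounds named here, the one single-point step measured so far, a 1.9-fold lower number from compound 1 to compound 2 (0.27 log units; within the scatter), is within the scatter. Compound 3 sits within the scatter of compound 1 and beyond the scatter from compound 2, so its number separates from compound 2 only.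

Compound 4 `C/C(C(=O)NC1CC1)=C(/C)c1ccc(C)cc1` has not yet been measured in this assay. Its difference from compound 3 is cyclopropyl in place of allyl on an amide-type nitrogen whose other neighbour is a carbonyl carbon; cut one bond further out it reads allylamino to cyclopropylamino. Going by the values given here, no measured step touches this nitrogen: the only step measured, fluoro for bromo, sits on the aromatic ring and is itself within the scatter, so it carries no direction over to the amide side. With nothing pointing either way, the expectation for compound 4 is a step of no change at the digits printed from compound 3 to compound 4 (within the scatter) in this assay, none beyond the scatter. Compound 4 is therefore estimated at 150 mg/kg, with a range from 75 mg/kg to 300 mg/kg.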

Compound 4, dose for half-maximal effect: 150 mg/kg
Compound 4: the middle estimate sits on the measured number at the digits printed; the range from low to high includes it.
By their numbers in this assay, from the lowest: compounds 2, 1, 3 and 4 (each within the scatter of the next, the first and the last beyond it).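

Working notes: in this assay, no change at the digits printed from compound 3 to compound 4 (within the scatter) is the only step on the amide-type nitrogen in this set, and it shows that exchanging allyl, with its double bond, for cyclopropyl, with its three-membered ring of carbon, at the same count of heavy atoms leaves the number within the scatter. With cyclopropyl held on the nitrogen, methyl in place of fluoro on an aromatic carbon gives a 2.1-fold higher number from compound 2 to compound 4 (0.33 log units; beyond the scatter) as the only single-place step here beyond the scatter, whereas methyl in place of bromo gives a 1.2-fold higher number from compound 1 to compound 4 (0.06 log units; within the scatter) and stays within it, so among these four compounds the aromatic carbon, and not the nitrogen, carries the one separable step. No supporting data bear on the reason for either outcome.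

As far as these compounds go, it remains open whether the nitrogen stays equally flat with a group of another kind there, such as a longer chain like n-butyl or a chain ending in a carboxylic acid. Also open, from the compounds shown here alone, is whether a nitrile or a methoxy group on the aromatic carbon would extend the separation seen between fluoro and methyl.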